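Cytotoxicity Ceiling Held Across Benzyl Variants on a Shared Core

The compounds below may be only part of what the source reports. "The series", "measured", "known", "first", "only" and "open" are said of these compounds alone.

This account follows a series of ester-bearing compounds sharing one core and differing only in the group carried on a saturated chain carbon bound to an amine nitrogen in a ring. Compound 1 `CCOC(=O)c1cnc(N2CCN(Cc3ccccc3F)CC2)nc1Oc1c(C)cc(-c2ccc(C#N)cc2)cc1C` is the starting point. In an ADME assay on MT4 cells (Homo sapiens) for cytotoxicity, read by MTT assay, with a stated time of 4 days (on this read-out lower numbers stand for higher toxicity in this test and higher numbers for lower toxicity in this test), compound 1 gives > 125000 nM, which is a limit of the assay rather than a number. Compound 2 `CCOC(=O)c1cnc(N2CCN(Cc3ccc(S(C)(=O)=O)cc3)CC2)nc1Oc1c(C)cc(-c2ccc(C#N)cc2)cc1C` carries a 4-(methylsulfonyl)phenyl instead. In this assay compound 2 gives > 125000 nM, again a limit rather than a number. For the measured compounds named here, the step that the two limits leave unreadable from compound 1 to compound 2 therefore cannot be read in size, and the one piece of evidence available is the limit of > 125000 nM in this assay, at which 2 of the 2 values shown sit.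

Compound 3 `CCOC(=O)c1ccc(CN2CCN(c3ncc(C(=O)OCC)c(Oc4c(C)cc(-c5ccc(C#N)cc5)cc4C)n3)CC2)cc1` is not yet measured. It differs from compound 1 by 4-(ethoxycarbonyl)phenyl in place of 2-fluorophenyl on a saturated chain carbon bound to an amine nitrogen in a ring. Going by the values given here, the only measured step, from compound 1 to compound 2, offers no readable size, so nothing in the data points to a direction for compound 3 beyond the shared limit. Compound 3 is therefore expected to sit at the limit as well, with the step of a number no higher from compound 1 to compound 3 (the limit leaves the size open) expected to be unreadable. The estimate for compound 3 is 125000 nM, with a range from 60000 nM to 250000 nM.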

Compound 3, half-maximal cytotoxic concentration: > 125000 nM
Compound 3: no number, only a limit; the forecaster's own chance of this, stated with the estimate: 85%; the middle value sits exactly at the limit.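

In this assay compound 3 gives > 125000 nM, again a limit of the assay and not a number. Its steps from compound 1 and from compound 2 therefore cannot be read in size, and what remains is the shared limit: the limit of > 125000 nM in this assay, at which 3 of the 3 values shown sit.

The compounds shown leave open whether compound 1, compound 2 and compound 3 differ at all in this assay.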